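This account rests on a few compounds, and the source may have more. Where it says the series, first, only, none or still open, it means among the compounds named here.

Compound 1 `C[C@H]1NC(O)[C@H](O)[C@@H](O)[C@H]1O`: 3000 nM
Compound 2 `C[C@H]1N[C@@H](S(=O)(=O)O)[C@H](O)[C@@H](O)[C@H]1O`: 13000 nM

In an assay on isolated protein for inhibition of tissue alpha-L-fucosidase (Bos taurus) (on this read-out lower numbers stand for stronger inhibition and higher numbers for weaker inhibition), compound 2 gives the higher of the two numbers, and compound 1 gives a lower number, a gap beyond the scatter. Compound 3 `C[C@@H]1N[C@H](S(=O)(=O)O)[C@@H](O)[C@H](O)[C@@H]1O` differs from compound 2 in that (the two compounds have the same atoms and bonds and differ only in configuration as drawn: 5 of 5 stereo elements differ (all stereocentres are inverted: mirror images); a stereocentre at a saturated ring carbon is drawn R in compound 2 and S in compound 3; a stereocentre at a saturated ring carbon is drawn S in compound 2 and R in compound 3; a stereocentre at a saturated ring carbon is drawn R in compound 2 and S in compound 3; a stereocentre at a saturated ring carbon is drawn S in compound 2 and R in compound 3). Going by the values given here, no measured pair shows what such a change does here. The expectation is that compound 3 gives a weaker number than compound 2, a step of a 12-fold higher number from compound 2 to compound 3 (1.06 log units; beyond the scatter), with a fair chance that only a limit is reported. Compound 3 is estimated at 150000 nM in this assay, within 20000 nM to 1500000 nM.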

Compound 3, inhibition constant: 1 nM
Compound 3: middle estimate off by 150000-fold (5.18 log units), on the high side; the measured number lies below the stated range.
By their numbers in this assay, from the lowest: compound 3; then compound 1; then compound 2.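

Going to the mirror image gives a 13000-fold lower number from compound 2 to compound 3 (4.11 log units; beyond the scatter) in this assay with no atom or bond changed. The earlier compounds shown here said nothing about configuration, and this pair shows that configuration alone can decide this read-out on the shared core. The large step can be tied to that change alone: the fact that compounds 2 and 3 differ only in the configuration as drawn.

All the stereocentres invert together, and the compounds shown do not tell which of them carries the step. From the compounds shown here alone, how compound 3 would respond to a carboxylic acid in place of its sulfonic acid group also remains open.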